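Swapping cyclopropyl for an aromatic ring on the sulfonyl

The compounds below may be only part of what the source reports. "The series", "measured", "known", "first", "only" and "open" are said of these compounds alone.

- compound 1 `COc1ncc(-c2cc(OC)c3nc(N)nc(C)c3c2)cc1NS(=O)(=O)c1ccc(F)cc1F` gives 280 nM
- compound 2 `COc1ncc(-c2cc(OC3CCN(C)CC3)c3nc(N)nc(C)c3c2)cc1NS(=O)(=O)c1ccc(F)cc1F` gives 660 nM
- compound 3 `COc1ncc(-c2cc(OC3CCOCC3)c3nc(N)nc(C)c3c2)cc1NS(=O)(=O)C1CC1` gives 930 nM

In a functional assay on NCI-H460 cells (Homo sapiens) for cytotoxicity, read by MTT assay, with a stated time of 96 h (a lower number here means a stronger inhibitor, a higher number a weaker inhibitor), compound 3 gives 930 nM which lies within the usual scatter of compound 2, while compound 1 has a lower number, beyond the scatter. Compound 4 `COc1ncc(-c2cc(OC3CCOCC3)c3nc(N)nc(C)c3c2)cc1NS(=O)(=O)c1ccc(F)cc1Cl` brings one change to compound 3, and that change is 2-chloro-4-fluorophenyl in place of cyclopropyl on a sulfonyl sulfur with 2-chloro-4-fluorophenyl in place of cyclopropyl on a sulfonyl sulfur. Within the data shown here, the one measured single-place step is a 2.4-fold higher number from compound 1 to compound 2 (0.37 log units; beyond the scatter) and it sits on an oxygen, not on the sulfonyl sulfur, so it bears on this change only weakly. Among the measured compounds shown here, no measured step swaps the sulfonyl group itself. The closest guide is that compound 1 and compound 2 also carry an aromatic ring on the sulfonyl sulfur, with compound 2 at 660 nM and compound 1 at 280 nM in the same test. The estimated step is a 2.1-fold lower number from compound 3 to compound 4 (0.32 log units; beyond the scatter) and so a modest expected move toward a lower number. In this assay the estimate for compound 4 is 450 nM within an expected range of 160 nM to 1200 nM as a rough guide only.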

Compound 4, half-maximal inhibitory concentration: 17 nM
For compound 4 the middle estimate is 26-fold (1.42 log units) above the measured one, outside the stated range (below it).
By their numbers in this assay, from the lowest: compound 4; then compound 1; then compounds 2 and 3 (each within the scatter of the next).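

In this assay, the group on the sulfonyl sulfur proves to be a highly sensitive point in the molecule: 2-chloro-4-fluorophenyl in place of cyclopropyl gives a 55-fold lower number from compound 3 to compound 4 (1.74 log units; beyond the scatter). Among these compounds, since nothing else differs between these two compounds, this whole step belongs to that single exchange, which is the first direct reading of a change at this position. Nothing presented here explains why the exchange has so large an effect.

From the compounds shown here alone, a single step cannot separate the contribution of the aromatic ring from that of its chlorine and fluorine, so that question remains open. Going by these compounds, how a phenyl ring with neither halogen, or a longer carbon chain carrying an amine, would behave on the same sulfonyl sulfur also remains unknown.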